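Phenyl for Methyl in a Paw Edema Series

The compounds below may be only part of what the source reports. "The series", "measured", "known", "first", "only" and "open" are said of these compounds alone.

In a functional assay on the whole organism (strain albino) for inhibition, with Rattus norvegicus as the target, read by paw edema, with stated times of 30 min and 1 h, at a dose of 25 mg/kg by the intraperitoneal route (a lower number here means less inhibition, a higher number more inhibition at the dose given (going by the name of the read-out)), compound 2 `CCOC(=O)c1nn(-c2ccccc2)c(-c2ccc(OC)cc2OC)c1C` gives 4.9%. Compound 1 `CCOC(=O)c1nn(-c2ccccc2)c(-c2ccc(OC)cc2OC)c1-c1ccccc1` gives 17.7% in this assay, and the step of a number 12.8 percentage points higher from compound 2 to compound 1 (beyond the scatter) follows the change (phenyl in place of methyl on an aromatic carbon). Compound 3 `CCOC(=O)c1nn(-c2ccc(Cl)cc2)c(-c2ccc(OC)cc2OC)c1C` gives 0% in this assay; the step of a number 4.9 percentage points lower from compound 2 to compound 3 (within the scatter) rests on (chloro in place of hydrogen on an aromatic carbon), which is also how the core of compound 3 differs from the core of compound 2. Compound 4 `CCOC(=O)c1nn(-c2ccc(Cl)cc2)c(-c2ccc(OC)cc2OC)c1-c1ccccc1` has not been measured. It differs from compound 3 by phenyl in place of methyl on an aromatic carbon, the same kind of change as that from compound 2 to compound 1, though here the ring atom two ring bonds away bears a 4-chlorophenyl group rather than a phenyl group. A step of similar size is expected, a number 12 percentage points higher from compound 3 to compound 4 (beyond the scatter), beside the earlier one, because compound 3 gives 0%. Compound 4 is therefore estimated at 12%, between 0% and 25%.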

Compound 4, a percentage reported as inhibition, in the whole organism at one dose (the size of the read-out at that dose, not a potency): 6.89%
For compound 4 the middle estimate is 5.1 percentage points above the measured one; the measured number falls inside the stated range.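

In this assay, among the compounds shown here, phenyl in place of methyl on the core with the 4-chlorophenyl group gives a number 6.9 percentage points higher from compound 3 to compound 4 (within the scatter), and this does not differ from the same change on the other core: the same change on two cores in this assay, a number 12.8 percentage points higher (beyond the scatter) from compound 2 to compound 1 and a number 6.9 percentage points higher (within the scatter) from compound 3 to compound 4, 5.9 percentage points apart, within the scatter of two such steps Chloro in place of hydrogen, now read with phenyl on that carbon, gives a number 10.8 percentage points lower from compound 1 to compound 4 (beyond the scatter), and it too matches its earlier reading: the same change on two cores in this assay, a number 4.9 percentage points lower (within the scatter) from compound 2 to compound 3 and a number 10.8 percentage points lower (beyond the scatter) from compound 1 to compound 4, 5.9 percentage points apart, within the scatter of two such steps The changes thus carry across these two cores without a detectable difference, but this rests on only two pairs, and the step on the 4-chlorophenyl core alone does not clear the scatter, so it shows no gain there by itself.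

The compounds shown leave open whether an amine or a longer chain on that aromatic carbon would behave as phenyl does. They also leave open what a carboxylic acid in place of the ethoxycarbonyl group would give.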